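A sulfoximine in place of tert-butyl: expected cytotoxicity

A few compounds are considered here, and "the series" means these few. Any claim that something is new, unique, unknown or untested is made for them only; others in the source may bear on it.

Compound 1, `Cc1c(-c2ccc(Cc3ccc(C(C)(C)C)cc3)cc2)[nH]c2cccc(F)c2c1=O`, was examined in an ADME assay on Huh7.5.1 cells (Homo sapiens) for cytotoxicity, read by WST assay, with a stated time of 48 h; a lower number here means that less compound is tolerated, a higher number that more compound is tolerated. In this assay compound 1 gives > 5000 nM, which is a limit of the assay and not a number. Compound 2, `Cc1c(-c2ccc(Cc3ccc([S+]([O-])C(F)(F)F)cc3)cc2)[nH]c2cccc(F)c2c1=O`, carries a different group on the same aromatic carbon, and in this assay compound 2 gives > 5000 nM, again only a limit. The step that the two limits leave unreadable from compound 1 to compound 2 therefore cannot be read. Compound 3, `Cc1c(-c2ccc(Cc3ccc(S(=N)(=O)C(F)(F)F)cc3)cc2)[nH]c2cccc(F)c2c1=O`, differs from compound 1 by a group of 7 heavy atoms (1 carbon, 1 nitrogen, 1 oxygen, 3 fluorine, 1 sulfur; no ring) in place of a group of 4 heavy atoms (4 carbon; no ring), on an aromatic carbon. Going by the values given here, only one measured step bears on this change, and both of its ends sit at the same limit, as the limit of > 5000 nM in this assay, at which 2 of the 2 values shown sit, records, so the two values shown leave no readable size in either direction. Compound 3 is therefore expected to remain at that limit as well, and the step that the limit leaves unreadable from compound 1 to compound 3 is estimated to be nothing beyond the scatter. The estimate for compound 3 is 10000 nM, expected to fall between 5000 nM and 40000 nM.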

Compound 3, half-maximal cytotoxic concentration: > 10000 nM
Compound 3: only a limit was reported; the forecaster's own chance of this, stated with the estimate: 85%; the middle value lies on the limit itself.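

In this assay compound 3 gives > 10000 nM, which is a limit of the assay and not a number. Going by these compounds alone, compound 1, compound 2 and compound 3 all stand at limits, so no step among them can be read. From the compounds shown here alone, the actual half-maximal cytotoxic concentration of each compound stays open, and with it whether changing the group on the aromatic carbon alters tolerance at all.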